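The source may hold more compounds than are shown below. What is called first, only, known or untested is meant among the compounds shown, and "the series" means these compounds.

Measured so far:
- compound 1 `CNC(=O)[C@@]12C[C@@H]1[C@@H](n1cnc3c(NC)nc(C#Cc4ccccc4OC)nc31)[C@H](O)[C@@H]2O` — in an assay on CHO cells for displacement of a labelled ligand from adenosine receptor A3 (Homo sapiens), read by scintillation counting, with a stated time of 60 min (on this read-out lower numbers stand for stronger inhibition and higher numbers for weaker inhibition), compound 1 gives 0.77 nM
- compound 2 `CNC(=O)[C@@]12C[C@@H]1[C@@H](n1cnc3c(NC)nc(C#Cc4cnn(C)c4)nc31)[C@H](O)[C@@H]2O` — in this assay compound 2 gives 2.34 nM

Compound 2 stands at the highest of the two numbers, the nearest neighbour being compound 1 at a 3.0-fold higher number from compound 1 to compound 2 (0.48 log units; beyond the scatter). Within the data shown here, that single step, 1-methyl-1H-pyrazol-4-yl in place of 2-methoxyphenyl on a triple-bonded carbon, is the only comparison available, and it shows that swapping the group at the end of the alkyne moves the number only modestly.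

Compound 3 `CNC(=O)[C@@]12C[C@@H]1[C@@H](n1cnc3c(NC)nc(C#CC4CC4)nc31)[C@H](O)[C@@H]2O` is not yet measured. It differs from compound 2 as follows: cyclopropyl in place of 1-methyl-1H-pyrazol-4-yl on a triple-bonded carbon. Here the aromatic ring at the end of the alkyne is removed altogether and a small saturated ring takes its place. Among the measured compounds shown here, no measured step covers an aromatic-to-non-aromatic exchange in this position, so the expectation rests on the one step above: the series has so far tolerated changes at this carbon with modest shifts, and compound 3 is expected to sit a little above compound 2, with a step of a 1.9-fold higher number from compound 2 to compound 3 (0.28 log units; within the scatter) in this assay. Compound 3 is therefore estimated at 4.5 nM, with a range of 1.5 nM to 14 nM.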

Compound 3, inhibition constant: 1.15 nM
Beside the measured number, compound 3's estimate is 3.9-fold (0.59 log units) above it; measured number outside the range, below it.
By their numbers in this assay, from the lowest: compounds 1 and 3 (each within the scatter of the next); then compound 2.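

In this assay, this position proves not to depend on an aromatic ring at the end of the alkyne: a three-membered non-aromatic ring of carbon only, with no hydrogen-bond acceptors, replaces 1-methyl-1H-pyrazol-4-yl and gives (a 2.0-fold lower number from compound 2 to compound 3 (0.31 log units; beyond the scatter)), a modest step. Set against the 2-methoxyphenyl group, the same cyclopropyl gives (a 1.5-fold higher number from compound 1 to compound 3 (0.17 log units; within the scatter)), so among these three compounds the two aromatic groups do not both read apart from the saturated ring, and aromaticity alone does not sort the values. No measurement given here explains why the cyclopropyl compound reads as it does.

Going by these compounds, how far saturated groups carry at this triple-bonded carbon remains open, since a cyclohexyl ring or a longer chain such as n-butyl would test whether the result extends beyond the three-membered ring. Also open, on these data alone, is how a charged or hydrogen-bond-donating end group, such as a primary amine or a carboxylic acid, would read on the same alkyne with the rest of the shared core unchanged.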